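The compounds below may be only part of what the source reports. "The series", "measured", "known", "first", "only" and "open" are said of these compounds alone.

Measured compounds in a functional assay on L929 cells (Mus musculus) for inhibition; a lower number here means a stronger inhibitor of growth, a higher number a weaker inhibitor of growth:
Compound 1 `Nc1nn2c(O)cc(-c3ccccc3F)nc2c1[N+](=O)[O-]` gives only the assay limit > 50 ug/mL.
Compound 2 `Nc1nn2c(O)cc(-c3ccc(F)cc3)nc2c1[N+](=O)[O-]` gives only the assay limit > 50 ug/mL.
Compound 3 `COc1ccc(NNCc2cc(O)n3nc(N)c([N+](=O)[O-])c3n2)cc1` gives only the assay limit > 50 ug/mL.

All three values sit at the limit of this assay (the limit of > 50 ug/mL in this assay, at which 3 of the 3 values shown sit). Among the measured compounds shown here, the only step between measured compounds is a step that the two limits leave unreadable from compound 1 to compound 2. Compound 3 therefore stands at that limit, and the two other values are limits as well, so no ranking among the three is possible. Compound 4 `Nc1nn2c(O)cc(CNNCCO)nc2c1[N+](=O)[O-]` differs from compound 3 by 2-hydroxyethyl in place of 4-methoxyphenyl on an amine nitrogen. For the measured compounds named here, no measured step bears on this change. With every value in this assay at the limit, the step that the limit leaves unreadable from compound 3 to compound 4 is expected to stay within the scatter. Compound 4 is estimated at 80 ug/mL, from 30 ug/mL to 300 ug/mL.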

Compound 4, concentration for 50% growth inhibition: > 50 ug/mL
Compound 4 gave a limit, no number; the forecaster's own chance of this, stated with the estimate: 85%; the middle value lies beyond the limit too.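

In this assay compound 4 gives > 50 ug/mL, a limit and not a number. Its steps to compound 1, compound 2 and compound 3 therefore cannot be read: the limit of > 50 ug/mL in this assay, at which 4 of the 4 values shown sit.

The compounds shown leave open how strongly any of the four inhibits growth, and what any change on the shared core does to that inhibition.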